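Compound 3 and the Cytotoxicity Limit

A few compounds are considered here, and "the series" means these few. Any claim that something is new, unique, unknown or untested is made for them only; others in the source may bear on it.

In an ADME assay on HEK293 cells (Homo sapiens) for cytotoxicity, read by luminescence, with a stated time of 72 h (on this read-out lower numbers stand for an effect already at smaller amounts and higher numbers for an effect only at larger amounts of compound), compound 1 (`CCOC(=O)c1c(-c2cccc(OC(F)(F)F)c2)[nH]c2cc(OC)ccc2c1=O`) gives > 22000 nM, which is a limit of the assay and not a number. Compound 2 (`CCOC(=O)c1c(-c2cccc(Oc3ccccc3)c2)[nH]c2cc(OC)c(F)cc2c1=O`) gives > 22000 nM, also a limit, so its standing is known only as a limit. Going by the values given here, no step between measured compounds is available to set a size for the change that follows.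

Compound 3 (`CCOC(=O)c1c(-c2cccc(OC(F)(F)F)c2)[nH]c2cc(OC)c(F)cc2c1=O`) has trifluoromethyl in place of phenyl on an oxygen on an aromatic ring, which also reads as phenoxy to trifluoromethoxy. Compound 1 also carries trifluoromethoxy, and its result of > 22000 nM is a limit too. In this assay, the expected size of the step that the limit leaves unreadable from compound 2 to compound 3 is none beyond the usual scatter, with no direction expected. For compound 3 the estimated value is 24000 nM, with an expected range from 14000 nM to 45000 nM.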

Compound 3, half-maximal effective concentration: > 22000 nM
Compound 3: no number, only a limit; the forecaster's own chance of this, stated with the estimate: 85%; the middle value is on the limit's open side.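

Compound 3 ends at a limit and not a number, as do compound 1 and compound 2, so no step from either compound to compound 3 can be read: the limit of > 22000 nM in this assay, at which 3 of the 3 values shown sit.

The compounds shown leave open whether phenoxy to trifluoromethoxy, or fluoro in place of hydrogen, changes the result in this assay at all.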